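Tolerance in Liver Cells: From Compound 3 to Compound 4

This account rests on a few compounds, and the source may have more. Where it says the series, first, only, none or still open, it means among the compounds named here.

Compound 1 `CCCCC(CC)CNc1ncc(C(Oc2ccc3cc(Br)ccc3c2)c2ccc(Cl)cc2)s1`: "not toxic" (no number reported)
Compound 2 `Cc1ccc(C(=O)Nc2ncc(C(Oc3ccc4cc(Br)ccc4c3)c3ccc(Cl)cc3)s2)cc1`: "not toxic" (no number reported)
Compound 3 `O=C(Nc1ncc(C(Oc2ccc3cc(Br)ccc3c2)c2ccc(Cl)cc2)s1)c1ccc(F)cc1Br`: > 50000 nM

In an ADME assay on HepG2 2.2.15 cells (Homo sapiens) for cytotoxicity (a higher number here means that more compound is tolerated, a lower number that less compound is tolerated), compound 1 gives "not toxic" (no number reported) without a number. In this assay compound 2 likewise gives "not toxic" (no number reported) without a number. In this assay compound 3 gives > 50000 nM, which is a limit of the assay and not a measured number. For the measured compounds named here, compound 3 therefore stands at the limit of > 50000 nM in this assay, at which 1 of the 3 values shown sits; it has only a limit, and the two other entries carry no number at all, so no measured step between compounds of this shared core exists.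

Compound 4 `O=S(=O)(Nc1ncc(C(Oc2ccc3cc(Br)ccc3c2)c2ccc(Cl)cc2)s1)c1ccc(Cl)nc1` remains to be measured in this assay. It differs from compound 3 in one place: (6-chloropyridin-3-yl)sulfonyl in place of (2-bromo-4-fluorophenyl)carbonyl on a nitrogen on an aromatic ring

Going by the values given here, with no measured step to lean on, the change from compound 3 to compound 4 in this assay is expected to stay within the scatter, and the estimated step is a number no higher from compound 3 to compound 4 (the limit leaves the size open). Compound 4 is accordingly expected to give 50000 nM, within 20000 nM to 120000 nM, and most likely to be reported again only as a limit.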

Compound 4, half-maximal cytotoxic concentration: "not toxic" (no number reported)
Compound 4 has no reported number here; the estimate stays without a comparison.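

In this assay compound 4 gives "not toxic" (no number reported). For the compounds shown here, compound 3 has only a limit, so no step between compound 3 and compound 4 can be read. The compounds shown leave open how much of each compound the cells tolerate, and whether exchanging the (2-bromo-4-fluorophenyl)carbonyl for the (6-chloropyridin-3-yl)sulfonyl changes that tolerance at all.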